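The source may hold more compounds than are shown below. What is called first, only, known or untested is meant among the compounds shown, and "the series" means these compounds.

Compound 3 `COc1cc(Cl)cc(-c2nn(-c3cccc(NC(=O)Nc4ccc(Cl)c(Cl)c4)c3)cc2-c2ccncc2)c1` gives 80% in a functional assay on UACC-257 cells (Homo sapiens) for inhibition, read by sulforhodamine B assay, with a stated time of 48 h, tested at 1 uM (on this read-out higher numbers stand for a weaker effect at the one concentration tested and lower numbers for a stronger effect), the second highest of the three numbers seen: compound 2 `O=C(Nc1cccc(-n2cc(-c3ccncc3)c(-c3cc(O)cc(Cl)c3)n2)c1)Nc1ccc(Cl)c(Cl)c1` gives 92%, while compound 1 `O=C(Nc1cccc(-n2cc(-c3ccncc3)c(-c3cc(O)cc(Cl)c3)n2)c1)Nc1ccc(Cl)c(C(F)(F)F)c1` gives 58%. Compound 4 `COc1cc(Cl)cc(-c2nn(-c3cccc(NC(=O)c4cccc(C(F)(F)F)c4)c3)cc2-c2ccncc2)c1` differs from compound 3 in one place: 3-(trifluoromethyl)phenyl in place of (3,4-dichlorophenyl)amino on a carbonyl carbon. Within the data shown here, two measured steps touch this series. The first, a number 34 percentage points higher from compound 1 to compound 2 (beyond the scatter), was large for chloro in place of trifluoromethyl; the second, a number 12 percentage points lower from compound 2 to compound 3 (beyond the scatter), was modest. Neither covers the removal of the amino link on the carbonyl carbon, so the size of the coming step is uncertain. Because compound 1 gives 58% with trifluoromethyl present, compound 4 is expected to move by a number 2 percentage points lower from compound 3 to compound 4 (within the scatter). The estimate for compound 4 is 78%, between 55% and 100%.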

Compound 4, a percentage reported as activity, at one concentration (the size of the read-out at that concentration, not a potency): 92%
The estimate for compound 4 lay 14 percentage points below the measured number; measured number inside the range.
By their numbers in this assay, from the lowest: compound 1; then compound 3; then compounds 2 and 4 (each within the scatter of the next).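

In this assay, among these compounds, the change on the carbonyl carbon gave a number 12 percentage points higher from compound 3 to compound 4 (beyond the scatter), so this position, untouched by the earlier steps, is not indifferent to the group it carries. The step combines loss of the amino link with a change of aromatic substituents, and the two cannot be separated here. No evidence available here accounts for the shift. Open, on these data alone, is which of the two parts matters, which a 3,4-dichlorophenyl group directly on the carbonyl carbon could help separate. Also open, as far as these compounds go, is how a non-aromatic group such as cyclohexyl would read there.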